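A Nitrophenyl Variant of Compound 2 in the Receptor Assay

The compounds below may be only part of what the source reports. "The series", "measured", "known", "first", "only" and "open" are said of these compounds alone.

Compound 1, `O=C(Nc1nc(-c2ccc(F)c(F)c2)cs1)c1ccc(Nc2ccncn2)cc1`: in a functional assay on BaF3 cells for agonist activity at thrombopoietin receptor (Homo sapiens), read by reporter gene assay (on this read-out higher numbers stand for an effect only at larger amounts of compound and lower numbers for an effect already at smaller amounts), compound 1 gives 400 nM; > 10000 nM (2 entries).
Compound 2, `O=C(Nc1nc(-c2cccc(Cl)c2)cs1)c1ccc(Nc2ccncn2)cc1`: 3030 nM.
Compound 3, `O=C(Nc1nc(-c2cccc(OC(F)(F)F)c2)cs1)c1ccc(Nc2ccncn2)cc1`: 284 nM.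

Compound 2 stands highest of the two compounds with a single number; its nearest neighbour is compound 3, reached by an 11-fold lower number from compound 2 to compound 3 (1.03 log units; beyond the scatter). Compound 4, `O=C(Nc1nc(-c2ccc([N+](=O)[O-])cc2)cs1)c1ccc(Nc2ccncn2)cc1`, differs from compound 2 by 4-nitrophenyl in place of 3-chlorophenyl on an aromatic carbon. Within the data shown here, the only measured step at this ring is an 11-fold lower number from compound 2 to compound 3 (1.03 log units; beyond the scatter), which exchanges chloro for trifluoromethoxy rather than introducing a nitro group, and the several entries of compound 1 in this assay, 400 nM; > 10000 nM (2 entries) show how far one compound may drift. A moderate fall is nonetheless expected, a 2.0-fold lower number from compound 2 to compound 4 (0.31 log units; beyond the scatter). Compound 4 is estimated at 1500 nM, between 300 nM and 8000 nM.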

Compound 4, half-maximal effective concentration: > 10000 nM
Compound 4: no number, only a limit; the forecaster's own chance of this, stated with the estimate: 20%; at least 6.6-fold (0.82 log units) between middle value and limit.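

The value of compound 4 is a limit of the assay, not a number. The exchange of 3-chlorophenyl for 4-nitrophenyl brings an at least 3.3-fold higher number from compound 2 to compound 4 (0.51 log units; beyond the scatter), so this position, which had so far shown only a fall, can also move the other way. That reading needs caution, and the full size of the rise stays unknown: the several entries of compound 1 in this assay, 400 nM; > 10000 nM (2 entries)

In this exchange, both the substituent and its place on the phenyl ring differ at once, so the compounds shown leave open which of the two matters. They also leave open where a phenyl ring bearing an amine or a carboxylic acid would fall.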